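Swapping the aryl substituent on the piperazine amide

The compounds below may be only part of what the source reports. "The series", "measured", "known", "first", "only" and "open" are said of these compounds alone.

Compound 1 `CC1CC(=O)N(CC(=O)N2CCN(c3cccc(Cl)c3)CC2)C1=O` gives 100 mg/kg in a functional assay on the whole organism (strain CD1) with Mus musculus as the target, in the maximal electroshock model, with a stated time of 0.5 h; on this read-out lower numbers stand for an effect already at smaller amounts and higher numbers for an effect only at larger amounts of compound. On this read-out compound 1 is level with compound 3 `CCC1(C)CC(=O)N(CC(=O)N2CCN(c3ccccc3Cl)CC2)C1=O`, which gives 100 mg/kg; together they show the lowest numbers of the three measured compounds. Compound 2 `CC1CC(=O)N(CC(=O)N2CCN(c3ccccc3)CC2)C1=O` gives 300 mg/kg, and the step of a 3.0-fold higher number from compound 1 to compound 2 (0.48 log units; beyond the scatter) shows that taking the chloro away from the aromatic ring moves the number upward beyond the scatter.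

Compound 4 `Cc1ccccc1N1CCN(C(=O)CN2C(=O)CC(C)C2=O)CC1` has not yet been measured. It differs from compound 1 in one place: 2-methylphenyl in place of 3-chlorophenyl on an amine nitrogen in a ring. Going by the values given here, the only measured step that bears on this change is the one from compound 1 to compound 2, where the aromatic ring lost its substituent altogether. In compound 4 the ring keeps a substituent, a methyl rather than a chloro, at a different position. Among the compounds with values here, compound 3 carries a 2-chlorophenyl and gives the same number as compound 1, but it also differs in its core, so no single step links it to compound 4. A step smaller than that from compound 1 to compound 2 is therefore expected, in the same direction or none beyond the scatter. For compound 4 the estimated step is a 1.5-fold higher number from compound 1 to compound 4 (0.18 log units; within the scatter), giving an expected value of 150 mg/kg with a range from 70 mg/kg to 400 mg/kg.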

Compound 4, minimum effective dose: 300 mg/kg
For compound 4 the middle estimate is 2.0-fold (0.30 log units) below the measured one; low and high end bracket the measured number.
By their numbers in this assay, from the lowest: compounds 1 and 3 (each within the scatter of the next); then compounds 2 and 4 (each within the scatter of the next).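

In this assay, the step of a 3.0-fold higher number from compound 1 to compound 4 (0.48 log units; beyond the scatter) shows that keeping a substituent on the aromatic ring is not enough to hold the number at the level of compound 1: the 2-methylphenyl step is the same size as a 3.0-fold higher number from compound 1 to compound 2 (0.48 log units; beyond the scatter), the step that removes the chloro altogether. Going by these compounds alone, the step of no change at the digits printed from compound 2 to compound 4 (within the scatter) adds what the earlier compounds could not show, namely that methyl in place of hydrogen on this aromatic ring leaves the number where it was, so among the three compounds sharing the core of compound 1, only the 3-chlorophenyl of compound 1 stands apart from the other two. No measured evidence accounts for this result.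

The change from compound 1 to compound 4 alters both the group and its place on the ring, so the compounds shown do not separate the two, and compound 3, the only 2-chlorophenyl among them, also differs in its core. As far as these compounds go, it also stays open where a 3-methylphenyl, or a methoxy or nitrile on the same aromatic ring, would fall on this read-out.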